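This account rests on a few compounds, and the source may have more. Where it says the series, first, only, none or still open, it means among the compounds named here.

Measured in a functional assay on MCF7 cells (Homo sapiens) for antiproliferative activity, read by MTT assay, with a stated time of 48 h; a lower number here means a stronger inhibitor, a higher number a weaker inhibitor:
- compound 1 `N#Cc1cccc(Nc2ncnc3cc(NC(=O)/C=C/c4ccccc4)sc23)c1` gives > 100000 nM (a limit)
- compound 2 `O=C(/C=C/c1ccccc1)Nc1cc2ncnc(Nc3ccc(F)c(Cl)c3)c2s1` gives 30900 nM
- compound 3 `O=C(/C=C/c1ccccc1)Nc1cc2ncnc(Nc3cc(Cl)cc(Cl)c3)c2s1` gives > 100000 nM (a limit)

Compound 3 stands at the limit of > 100000 nM in this assay, at which 2 of the 3 values shown sit, and so gives no number. Compound 4 `O=C(/C=C/c1ccccc1)Nc1cc2ncnc(Nc3ccc(Cl)c(Cl)c3)c2s1` carries one change (3,4-dichlorophenyl in place of 3,5-dichlorophenyl on a nitrogen on an aromatic ring), 3,4-dichlorophenyl in place of 3,5-dichlorophenyl. Two readable steps at this place bear on it (an at least 3.2-fold lower number from compound 1 to compound 2 (0.51 log units; beyond the scatter); an at least 3.2-fold higher number from compound 2 to compound 3 (0.51 log units; beyond the scatter)), both of modest minimum size. A third step (a step that the two limits leave unreadable from compound 1 to compound 3) has no readable size. Going by the values given here, the expected step (an at least 2.5-fold lower number from compound 3 to compound 4 (0.39 log units; beyond the scatter)) in this assay is a modest one toward lower numbers, resting on compound 2 at 30900 nM as the only exact reading. For compound 4 the estimated value is 40000 nM (expected range 12000 nM to 100000 nM).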

Compound 4, half-maximal inhibitory concentration: > 100000 nM
Compound 4: only a limit was reported (the forecaster's own chance of this, stated with the estimate: 35%); middle value at least 2.5-fold (0.39 log units) from the limit.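

In this assay compound 4 gives > 100000 nM as a limit, not a number. Chloro in place of fluoro on an aromatic carbon gives an at least 3.2-fold higher number from compound 2 to compound 4 (0.51 log units; beyond the scatter) and leaves compound 2 as the only exact reading, so 3,4-dichlorophenyl in place of 3,5-dichlorophenyl does not bring a readable value. The steps to compound 4 from compound 1 and compound 3 cannot be read, with limits at both ends: the limit of > 100000 nM in this assay, at which 3 of the 4 values shown sit.

Still open, on these data alone, is whether a methoxy or a bromo in place of the fluoro of compound 2 keeps a readable value.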